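The source may report more compounds than this note shows. Statements on the series, on what has been measured and on what is new or still open speak of the compounds shown alone.

Measured so far:
compound 1 `OC[C@H]1O[C@@H](n2cnc3c(Cn4ccc5ccccc54)ncnc32)[C@H](O)[C@@H]1O` gives > 250000 nM in a functional assay on Huh-7 cells (Homo sapiens) for cytotoxicity, read by MTT assay, with a stated time of 3 days; on this read-out lower numbers stand for higher toxicity in this test and higher numbers for lower toxicity in this test
compound 2 `CC(=O)N(Cc1ncnc2c1ncn2[C@@H]1O[C@H](CO)[C@@H](O)[C@H]1O)C1CCCCC1` gives > 100000 nM in this assay

Both readings are limits of the assay rather than numbers. Compound 1 stands at the limit of > 250000 nM in this assay, at which 1 of the 2 values shown sits. Compound 2 stands at the limit of > 100000 nM in this assay, at which 1 of the 2 values shown sits. Compound 3 `CSCc1ncnc2c1ncn2[C@@H]1O[C@H](CO)[C@@H](O)[C@H]1O` differs from compound 1 by methylsulfanyl in place of 1H-indol-1-yl on a saturated chain carbon bound to an aromatic carbon. Within the data shown here, no step between measured compounds is available to weigh this change, so in this assay no step beyond the usual scatter is expected, in no set direction. Compound 3 is therefore expected to give about 200000 nM, within 80000 nM to 500000 nM. The expected step is an at least 1.2-fold lower number from compound 1 to compound 3 (0.09 log units; that floor lies within the scatter).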

Compound 3, half-maximal cytotoxic concentration: > 100000 nM
Compound 3 was reported as a limit (the forecaster's own chance of this, stated with the estimate: 80%); the middle value lies beyond the limit too.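

Compound 1 and compound 3 are both reported only as limits in this assay, and the step between them cannot be read. The compounds shown leave open at what concentration any of them would become toxic to these cells.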